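The source may report more compounds than this note shows. Statements on the series, on what has been measured and on what is new or still open speak of the compounds shown alone.

Three related compounds have been measured in a functional assay on COLO 205 cells (Homo sapiens) for inhibition, read by sulforhodamine B assay, with a stated time of 48 h, tested at 50 uM (on this read-out lower numbers stand for less inhibition of growth and higher numbers for more inhibition of growth at the one concentration tested), and their values lie far apart. Compound 1 (`COc1cc(/C=C/C(=O)/C=C/c2cccc3ccccc23)ccc1OCc1cn(CCOc2cc(=O)oc3ccccc23)nn1`) gives 85% and stands highest of the three. Compound 3 (`COc1cc(/C=C/C(=O)/C=C/c2cc(OC)c(OC)c(OC)c2)ccc1OCc1cn(CCCCOc2cc(=O)oc3ccccc23)nn1`) gives 60% and compound 2 (`COc1ccc(/C=C/C(=O)/C=C/c2ccc(OCc3cn(CCCCCOc4cc(=O)oc5ccccc45)nn3)c(OC)c2)cc1OC`) gives 43% in the same test, both lower than compound 1 by more than the scatter.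

Compound 4 (`COc1cc(/C=C/C(=O)/C=C/c2ccco2)ccc1OCc1cn(CCOc2cc(=O)oc3ccccc23)nn1`) has not yet been measured. It differs from compound 1 in one place (furan-2-yl in place of naphthalen-1-yl on a double-bonded chain carbon bound to a double-bonded chain carbon), with furan-2-yl in place of naphthalen-1-yl on a double-bonded chain carbon bound to a double-bonded chain carbon. The rest of compound 1 stays as it is.

Among the compounds with values here, no two measured compounds differ in only one place, so the data give no direct size for this change. The expectation rests on the standing of compound 1 (85%) at the top of the measured values, which makes a lower result for a close relative more likely than a higher one. The expected change in this assay is a number 17 percentage points lower from compound 1 to compound 4 (beyond the scatter) and this estimated fall in growth inhibition would probably lie beyond the scatter, though with much uncertainty. For compound 4 the estimated value is 68% (expected range 45% to 88%).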

Compound 4, percent growth inhibition at one concentration: 68%
For compound 4 middle estimate and measured number coincide at the digits printed; measured number inside the range.
By their numbers in this assay, from the lowest: compound 2; then compounds 3 and 4 (each within the scatter of the next); then compound 1.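

The change from naphthalen-1-yl to furan-2-yl, on a double-bonded chain carbon bound to a double-bonded chain carbon, now has a direct size: a number 17 percentage points lower from compound 1 to compound 4 (beyond the scatter) in this assay at the one concentration tested. The smaller group, with 5 heavy atoms and one five-membered aromatic ring in place of 10 heavy atoms and 2 six-membered aromatic rings, does not abolish the read-out, as compound 4 still gives 68% in this test. Nothing shown accounts for the fall in growth inhibition.

This single step cannot separate the effect of the smaller ring system from that of the ring oxygen, a question that a phenyl or thiophen-2-yl group at the same place would address. It also leaves open whether the same swap would give a step of similar size with a longer chain on the other side of the molecule, and compound 2 and compound 3 cannot settle this, as each differs from compound 1 in more than one place.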